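The compounds below may be only part of what the source reports. "The series", "measured", "known", "first", "only" and "open" are said of these compounds alone.

Compounds measured so far:
- Compound 1 `Oc1cccc(-c2cc(-c3cccs3)cc(-c3ccccc3O)n2)c1`: in a functional assay on HeLa cells (Homo sapiens) for cytotoxicity, read by CCK-8 assay (on this read-out lower numbers stand for stronger inhibition and higher numbers for weaker inhibition), compound 1 gives > 50000 nM, which is a limit of the assay and not a number.
- Compound 2 `Oc1cccc(-c2cc(-c3ccco3)cc(-c3ccccc3O)n2)c1`: in this assay compound 2 gives > 50000 nM, again a limit.
- Compound 3 `Oc1ccccc1-c1cc(-c2cccnc2)cc(-c2ccccc2O)n1`: in this assay compound 3 gives > 50000 nM, also a limit.

The one step that can be traced among these, a step that the two limits leave unreadable from compound 1 to compound 2, is left unreadable by the two limits. Compound 3 therefore stands where every value shown stands, namely at the limit of > 50000 nM in this assay, at which 3 of the 3 values shown sit.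

Compound 4 `Oc1cccc(-c2cc(-c3cccnc3)cc(-c3ccccc3O)n2)c1` differs from compound 3 by 3-hydroxyphenyl in place of 2-hydroxyphenyl on an aromatic carbon. Among the measured compounds shown here, no measured step bears on this change; the only computed step concerns a different position and is itself unreadable. For the measured compounds named here, with all values so far sitting at the limit, there is no sign in this assay of any compound reaching measurable inhibition, and the expectation for compound 4 is the same: a step that the limit leaves unreadable from compound 3 to compound 4 that is expected to be none beyond the scatter. Compound 4 is estimated at 100000 nM, between 40000 nM and 300000 nM, and is expected to be reported once more as a limit.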

Compound 4, half-maximal inhibitory concentration: 7530 nM
Compound 4: the middle estimate sits 13-fold (1.12 log units) above what was measured; the measured number lies below the stated range.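

In this assay, with pyridin-3-yl held, 3-hydroxyphenyl in place of 2-hydroxyphenyl next to the ring nitrogen gives an at least 6.6-fold lower number from compound 3 to compound 4 (0.82 log units; beyond the scatter), so this position responds to where the hydroxyl sits on the phenyl group. With 3-hydroxyphenyl held, pyridin-3-yl in place of furan-2-yl gives an at least 6.6-fold lower number from compound 2 to compound 4 (0.82 log units; beyond the scatter), and pyridin-3-yl in place of thiophen-2-yl gives an at least 6.6-fold lower number from compound 1 to compound 4 (0.82 log units; beyond the scatter). Among these four compounds, a number rather than a limit appears only where 3-hydroxyphenyl and pyridin-3-yl occur together, in compound 4.

On these data alone, the full size of these steps stays open because the other compounds give only a limit: the limit of > 50000 nM in this assay, at which 3 of the 4 values shown sit. Also open is how this assay would read with an aminophenyl or a methoxyphenyl group in place of 3-hydroxyphenyl.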